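The source may hold more compounds than are shown below. What is called first, only, known or untested is meant among the compounds shown, and "the series" means these compounds.

Compound 1 `C#CCOc1ccc(C(=O)c2cccc(Cn3ccnc3)c2)cc1` gives the lowest number of the three measured in an assay on isolated protein for inhibition of Aromatase (Homo sapiens), read by fluorescence, with stated times of 10 min and 60 min (on this read-out higher numbers stand for weaker inhibition and lower numbers for stronger inhibition), at 650 nM. Compound 2 `CCCCCOc1ccc(C(=O)c2ccc(Cn3ccnc3)cc2)cc1` gives 1300 nM in this assay, a gap to compound 1 that lies within the scatter, while compound 3 `CCC#CCOc1ccc(C(=O)c2ccc(Cn3ccnc3)cc2)cc1` gives 1430 nM, a gap that lies just beyond it. For the measured compounds named here, the one single-point step measured, a 1.1-fold higher number from compound 2 to compound 3 (0.04 log units; within the scatter), changes only the chain attached to the oxygen and leaves the number essentially unchanged. Compound 4 `COc1ccc(C(=O)c2cccc(Cn3ccnc3)c2)cc1` differs from compound 1 by hydrogen in place of ethynyl on a saturated chain carbon bound to an oxygen on an aromatic ring. Going by the values given here, no measured step removes this chain outright, so only a modest weakening is expected, giving for compound 4 an estimate of 1500 nM (range 500 nM to 5000 nM), a step of a 2.3-fold higher number from compound 1 to compound 4 (0.36 log units; beyond the scatter) expected from compound 1.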

Compound 4, half-maximal inhibitory concentration: 13 nM
Estimate against measurement, compound 4: 120-fold (2.06 log units) above; the measured number lies below the stated range.
By their numbers in this assay, from the lowest: compound 4; then compounds 1, 2 and 3 (each within the scatter of the next, the first and the last beyond it).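

In this assay, cutting propargyloxy back to methoxy gives a 50-fold lower number from compound 1 to compound 4 (1.70 log units; beyond the scatter) and so much stronger inhibition. The chain on this oxygen therefore can carry a large change, which a 1.1-fold higher number from compound 2 to compound 3 (0.04 log units; within the scatter) on the core of compounds 2 and 3 did not reveal. No evidence at hand accounts for the size of this step.

On these data alone, whether methoxy is special or any short chain would serve remains open, as an ethoxy or a hydroxyl group in its place would test. Also open, as far as these compounds go, is whether methoxy gives the same gain on the core of compound 2.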